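Swapping the Protected Side Chain for Isobutyl

The compounds below may be only part of what the source reports. "The series", "measured", "known", "first", "only" and "open" are said of these compounds alone.

Three compounds built on the same core differ only in the side chain on the amino-acid-like carbon. Compound 1 `NC(=O)CC[C@H](NC(=O)CN(c1ncnc2c1ncn2C1CCCCO1)C1CC1)C(=O)OCc1ccccc1`, compound 2 `O=C(CN(c1ncnc2c1ncn2C1CCCCO1)C1CC1)N[C@@H](CCC(=O)OCc1ccccc1)C(=O)OCc1ccccc1` and compound 3 `CC(C)(C)OC(=O)NCCCC[C@H](NC(=O)CN(c1ncnc2c1ncn2C1CCCCO1)C1CC1)C(=O)OCc1ccccc1` were each tested in a functional assay on the whole organism (Tail, strain ICR) with Mus musculus as the target, in the tail flick test, with a stated time of 60 min, at a dose of 25 umol/kg by the oral route; on this read-out higher numbers stand for a stronger effect at the one dose given and lower numbers for a weaker effect. In this assay compound 1 gives 39.4%, compound 2 gives 34.7% and compound 3 gives 32.7%. Compound 3 thus holds the lowest of the three numbers, yet the steps of a number 6.7 percentage points lower from compound 1 to compound 3 (within the scatter) and a number 2 percentage points lower from compound 2 to compound 3 (within the scatter) both lie within the scatter, as does a number 4.7 percentage points lower from compound 1 to compound 2 (within the scatter), so the three cannot be told apart on these data.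

Compound 4 `CC(C)C[C@H](NC(=O)CN(c1ncnc2c1ncn2C1CCCCO1)C1CC1)C(=O)OCc1ccccc1` departs from compound 3 at that same carbon: isopropyl in place of 3-((tert-butoxycarbonyl)amino)propyl on a saturated chain carbon, two bonds along the chain from an amide-type nitrogen and a carbonyl carbon. The measured steps that bear on this change are the three side-chain exchanges already seen, none of which moved the read-out beyond the scatter, the largest being a number 6.7 percentage points lower from compound 1 to compound 3 (within the scatter). Replacing the 3-((tert-butoxycarbonyl)amino)propyl group with isopropyl is therefore expected to produce no step beyond the scatter in this assay, and the change a number 2.3 percentage points higher from compound 3 to compound 4 (within the scatter) is estimated to be small. Compound 4 is expected to give about 35%, with a range from 20% to 50%.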

Compound 4, a percentage reported as activity, at one dose (the size of the read-out at that dose, not a potency): 34.2%
For compound 4 the middle estimate is 0.8 percentage points above the measured one; low and high end bracket the measured number.
By their numbers in this assay, from the lowest: compounds 3, 4, 2 and 1 (each within the scatter of the next).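

With isopropyl at this carbon, on a saturated chain carbon two bonds along the chain from an amide-type nitrogen and a carbonyl carbon, this assay shows a number 1.5 percentage points higher from compound 3 to compound 4 (within the scatter) and a number 0.5 percentage points lower from compound 2 to compound 4 (within the scatter) and a number 5.2 percentage points lower from compound 1 to compound 4 (within the scatter) as the three new steps. The earlier exchanges compared only side chains that carry a carbonyl, whereas this one removes the 3-((tert-butoxycarbonyl)amino)propyl group of 11 heavy atoms, with its hydrogen-bond donor and acceptors, and puts in an all-carbon group of 3 heavy atoms, and the read-out still does not separate the compounds. No measurement at hand accounts for this flat picture at the position.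

Going by these compounds, what a free primary amine at the end of the chain or a free carboxylic acid on the side chain would do in this assay stays open, as does the effect of a cyclohexyl or phenyl ring at this carbon. Each number also comes from one dose, so these data give no potency, and side chains that cannot be told apart here might still separate at other doses.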